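Swapping the Six-Membered Ring for a Thiophene

A few compounds are considered here, and "the series" means these few. Any claim that something is new, unique, unknown or untested is made for them only; others in the source may bear on it.

Compound 1 `Cn1cccc1-c1ncnc2c1ncn2C1O[C@H](CO)[C@@H](O)[C@H]1O`: 15700 nM
Compound 2 `OC[C@H]1OC(n2cnc3c(-c4nccs4)ncnc32)[C@H](O)[C@@H]1O`: 6300 nM
Compound 3 `OC[C@H]1OC(n2cnc3c(-c4ccccn4)ncnc32)[C@H](O)[C@@H]1O`: 5600 nM

In a functional assay on HL-60 cells (Homo sapiens) for inhibition (a higher number here means a weaker inhibitor, a lower number a stronger inhibitor), compound 3 gives the lowest of the three numbers, but its gap to compound 2, a 1.1-fold lower number from compound 2 to compound 3 (0.05 log units; within the scatter), lies within the scatter, while a 2.8-fold lower number from compound 1 to compound 3 (0.45 log units; beyond the scatter) lies beyond it, so compound 3 is clearly separated only from compound 1. Compound 4 `OC[C@H]1OC(n2cnc3c(-c4ccsc4)ncnc32)[C@H](O)[C@@H]1O` differs from compound 3 by thiophen-3-yl in place of pyridin-2-yl on an aromatic carbon. Among the measured compounds shown here, two measured steps bear on this: a 1.1-fold lower number from compound 2 to compound 3 (0.05 log units; within the scatter) shows a 1,3-thiazol-2-yl keeping pace with pyridin-2-yl, whereas a 2.8-fold lower number from compound 1 to compound 3 (0.45 log units; beyond the scatter) shows 1-methyl-1H-pyrrol-2-yl falling behind. Thiophen-3-yl resembles the thiazole of compound 2 more closely, so the step is expected to stay within the scatter: a 1.3-fold higher number from compound 3 to compound 4 (0.10 log units; within the scatter). Compound 4 is therefore estimated at 7000 nM, within a range of 3500 nM to 15000 nM.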

Compound 4, half-maximal inhibitory concentration: 3800 nM
Compound 4: the middle estimate sits 1.8-fold (0.27 log units) above what was measured, within the range that was stated.
By their numbers in this assay, from the lowest: compounds 4, 3 and 2 (each within the scatter of the next); then compound 1.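

On the aromatic carbon that carries these rings, a five-membered thiophen-3-yl with sulfur as its only ring hetero atom holds up alongside both nitrogen-bearing rings in this assay: the data show a 1.5-fold lower number from compound 3 to compound 4 (0.17 log units; within the scatter) and a 1.7-fold lower number from compound 2 to compound 4 (0.22 log units; within the scatter). The one clear separation is a 4.1-fold lower number from compound 1 to compound 4 (0.62 log units; beyond the scatter), which leaves the 1-methyl-1H-pyrrol-2-yl group apart from this ring too. Nothing measured here explains why these numbers fall as they do. The compounds shown leave open whether this carbon needs an aromatic ring at all, which an amine or a short alkyl chain there could test.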